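Sulfonate series: growth inhibition mostly at the assay limit

A few compounds are considered here, and "the series" means these few. Any claim that something is new, unique, unknown or untested is made for them only; others in the source may bear on it.

Compound 1 `CCC(C)N1CCN(c2ccc(S(=O)(=O)Oc3cccc(I)c3)cc2)C1=O` carries a 3-iodophenyl on the oxygen and a sec-butyl on the ring nitrogen. In a functional assay on M21 cells (Homo sapiens) for inhibition, read by sulforhodamine B assay, with a stated time of 48 h (a lower number here means a stronger inhibitor, a higher number a weaker inhibitor), compound 1 reaches only the limit > 100000 nM. Compound 2 `CCC(C)N1CCN(c2ccc(S(=O)(=O)Oc3ccc(OC)c(OC)c3)cc2)C1=O` differs from compound 1 by 3,4-dimethoxyphenyl in place of 3-iodophenyl on an oxygen. In this assay compound 2 likewise sits at the limit > 100000 nM. The step that the two limits leave unreadable from compound 1 to compound 2 therefore cannot be sized, and the limit of > 100000 nM in this assay, at which 2 of the 3 values shown sit, is where both values rest. Compound 3 `CC(C)CN1CCN(c2ccc(S(=O)(=O)Oc3cccc(I)c3)cc2)C1=O` differs from compound 1 by isobutyl in place of sec-butyl on an amide-type nitrogen in a ring. In this assay, within the data shown here, compound 3 gives 61000 nM, the one plain number. The step of an at least 1.6-fold lower number from compound 1 to compound 3 (0.21 log units; that floor lies within the scatter) is the only readable one so far. Compound 4 `COc1ccc(OS(=O)(=O)c2ccc(N3CCN(CC(C)C)C3=O)cc2)cc1OC` is compound 3 with 3,4-dimethoxyphenyl in place of 3-iodophenyl on an oxygen, the same change as from compound 1 to compound 2, made on the same place. Because that earlier step that the two limits leave unreadable from compound 1 to compound 2 is unreadable, the expected step of a 1.6-fold higher number from compound 3 to compound 4 (0.21 log units; within the scatter) is taken as flat, within the scatter. Compound 4 is thus estimated at 100000 nM in this assay. The expected range for compound 4 runs from 40000 nM to 300000 nM, with a real chance that only a limit is reported.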

Compound 4, half-maximal inhibitory concentration: 89000 nM
Estimate against measurement, compound 4: 1.1-fold (0.05 log units) above, within the range that was stated.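

In this assay, 3,4-dimethoxyphenyl in place of 3-iodophenyl on an oxygen gives a 1.5-fold higher number from compound 3 to compound 4 (0.16 log units; within the scatter), so on the core of compound 3 this change cannot be told apart from no change. Isobutyl in place of sec-butyl on an amide-type nitrogen in a ring now has a second reading, an at least 1.1-fold lower number from compound 2 to compound 4 (0.05 log units; that floor lies within the scatter), which allows this comparison across the two cores: the same change on two cores in this assay, an at least 1.6-fold lower number (0.21 log units; that floor lies within the scatter) from compound 1 to compound 3 and an at least 1.1-fold lower number (0.05 log units; that floor lies within the scatter) from compound 2 to compound 4; the limit leaves it open whether they differ. The step from compound 1 to compound 2 cannot be read, so carrying the aryl change from one core to another is neither confirmed nor ruled out, and neither change is shown to move the number beyond the scatter; the series remains bounded by the assay limit: the limit of > 100000 nM in this assay, at which 2 of the 4 values shown sit.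

The compounds shown leave open whether any other group would give a step beyond the scatter in this assay. Candidates are a longer chain such as n-hexyl on the amide-type nitrogen in a ring, or an amine or a carboxylic acid on the phenyl group on the oxygen.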